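Phenylsulfanyl for phenylsulfonyl on the diethylamino amide

A few compounds are considered here, and "the series" means these few. Any claim that something is new, unique, unknown or untested is made for them only; others in the source may bear on it.

Measured in an ADME assay on microsomes from liver (Rattus norvegicus) for metabolic stability, read by HPLC, using NADPH; a higher number here means that the compound lasts longer, a lower number that the compound disappears faster:
compound 1 `CCn1c(C(=O)NCCN)ccc1C(CC)(CC)c1ccc(OCS(=O)(=O)c2ccccc2)c(C)c1` gives 0.582 h
compound 2 `CCN(CC)CCNC(=O)c1ccc(C(CC)(CC)c2ccc(OCS(=O)(=O)c3ccccc3)c(C)c2)n1CC` gives 1.04 h
compound 3 `CCn1c(C(=O)N[C@H](CO)C(C)C)ccc1C(CC)(CC)c1ccc(OCS(=O)(=O)c2ccccc2)c(C)c1` gives 0.772 h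

Compound 2, at 1.04 h, cannot be separated from the other two, with a 1.3-fold lower number from compound 2 to compound 3 (0.13 log units; within the scatter) and a 1.8-fold higher number from compound 1 to compound 2 (0.25 log units; within the scatter). Compound 4 `CCN(CC)CCNC(=O)c1ccc(C(CC)(CC)c2ccc(OCSc3ccccc3)c(C)c2)n1CC` carries phenylsulfanyl in place of phenylsulfonyl on a saturated chain carbon bound to an oxygen on an aromatic ring.

Among the compounds with values here, none of the measured steps touches this place. All three change only the group on the amide-type nitrogen: a 1.8-fold higher number from compound 1 to compound 2 (0.25 log units; within the scatter), a 1.3-fold higher number from compound 1 to compound 3 (0.12 log units; within the scatter) and a 1.3-fold lower number from compound 2 to compound 3 (0.13 log units; within the scatter). They show that such changes stayed within the scatter in this assay, but they give no size or direction for the present change. A modest downward step is expected, as a judgement without measured support, and a wide range is kept. The expected step is a 1.7-fold lower number from compound 2 to compound 4 (0.24 log units; within the scatter). For compound 4 the estimated half-life is 0.6 h, with an expected range of 0.2 h to 1.4 h.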

Compound 4, half-life: 0.895 h
Estimate against measurement, compound 4: 1.5-fold (0.17 log units) below, and the stated range covers the measured number.
By their numbers in this assay, from the lowest: compounds 1, 3, 4 and 2 (each within the scatter of the next).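

In this assay, phenylsulfanyl in place of phenylsulfonyl on a saturated chain carbon bound to an oxygen on an aromatic ring gives a 1.2-fold lower number from compound 2 to compound 4 (0.07 log units; within the scatter), so this place, like the group on the amide-type nitrogen, has so far shown no step beyond the scatter. The exchange takes the group from 2 hydrogen-bond acceptors to 1 and removes 2 double bonds outside aromatic rings, yet the read-out does not separate the two groups on this single pair. Nothing available gives a reason for this outcome.

As far as these compounds go, whether the same exchange also stays within the scatter with the 2-aminoethyl group of compound 1 on the amide-type nitrogen remains open. Also open, from the compounds shown here alone, is how phenoxy or phenylamino in place of phenylsulfanyl would read at this place.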